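A few compounds are considered here, and "the series" means these few. Any claim that something is new, unique, unknown or untested is made for them only; others in the source may bear on it.

Measured in a functional assay on M21 cells (Homo sapiens) for antiproliferative activity, with a stated time of 48 h; a lower number here means a stronger inhibitor, a higher number a weaker inhibitor:
Compound 1 `CCCCC(O)c1cccc(NC(=O)NC(=O)CCl)c1` gives 4600 nM.
Compound 2 `CCCCC(O)c1cccc(NC(=O)NC(=O)CC)c1` gives > 100000 nM, which is a limit of the assay.
Compound 3 `CCCCC(O)c1cccc(NC(=O)CCCl)c1` gives > 100000 nM, which is a limit of the assay.

Compound 3 therefore stands at the weak end of what has been measured, at the limit of > 100000 nM in this assay, at which 2 of the 3 values shown sit, and no number is known for it. Compound 4 `C=CC(=O)Nc1cccc(C(O)CCCC)c1` differs from it by vinyl in place of 2-chloroethyl on a carbonyl carbon. Among the measured compounds shown here, none of the measured steps covers this vinyl for 2-chloroethyl exchange. The nearest ones concern the chloro-bearing chain: an at least 21-fold higher number from compound 1 to compound 2 (1.33 log units; beyond the scatter), and an at least 21-fold higher number from compound 1 to compound 3 (1.33 log units; beyond the scatter), both large weakenings when the chloroacetyl urea of compound 1 is altered. The pair of compound 2 and compound 3 is a step that the two limits leave unreadable from compound 2 to compound 3. Since compound 3 sits at a limit, any step to compound 4 in this assay can only be read as a return from the limit or as no change; the measured steps give no direction for a vinyl group. Compound 4 is estimated at 30000 nM, within 3000 nM to 100000 nM. The step this implies, an at least 3.3-fold lower number from compound 3 to compound 4 (0.52 log units; beyond the scatter), is an expectation only, with a fair chance that compound 4 again reports a limit.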

Compound 4, half-maximal inhibitory concentration: 98000 nM
The estimate for compound 4 lay 3.3-fold (0.51 log units) below the measured number; the range from low to high includes it.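

Replacing 2-chloroethyl with vinyl on a carbonyl carbon brings no readable gain in this assay: the change is an at least 1.0-fold lower number from compound 3 to compound 4 (0.00 log units; that floor lies within the scatter), and the exchange of propanoylamino for vinyl is an at least 1.0-fold lower number from compound 2 to compound 4 (0.00 log units; that floor lies within the scatter). No more than these two floors can be stated, because compound 2 and compound 3 carry no number, only a limit: the limit of > 100000 nM in this assay, at which 2 of the 4 values shown sit. What compound 4 adds is a measured value for a compound without the urea of compound 1, and that value still leaves it far from compound 1, with a 21-fold higher number from compound 1 to compound 4 (1.33 log units; beyond the scatter); of the four compounds, only compound 1 stands clearly apart from the others.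

As far as these compounds go, it remains open whether the activity of compound 1 rests on the chloro atom, on the urea, or on both together, and how a vinylcarbonyl urea or a bromoacetyl urea on the shared core would behave in this assay. Also open, from the compounds shown here alone, is whether an amine or a carboxylic acid in place of the hydroxyl group, or a longer chain in place of the butyl chain, would move any of these values.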